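Removing the second acetyl from compound 3

This account rests on a few compounds, and the source may have more. Where it says the series, first, only, none or still open, it means among the compounds named here.

Among the three compounds measured in a functional assay on HeLa cells (Homo sapiens) for cytotoxicity, read by sulforhodamine B assay, with a stated time of 48 h (a lower number here means a stronger inhibitor, a higher number a weaker inhibitor), compound 3 `CCCC[C@@H](/C=C\[C@@H]1OC(=O)C=C[C@@H]1O)OC(C)=O` stands lowest, at 300 nM. Compound 1 `CCCC[C@@H](/C=C\[C@@H]1OC(=O)C=C[C@@H]1OC(C)=O)OC(C)=O` gives 3200 nM and compound 2 `CCCC[C@H](O)/C=C\[C@@H]1OC(=O)C=C[C@@H]1OC(C)=O` gives 4100 nM. Compound 4 `CCCC[C@H](O)/C=C\[C@@H]1OC(=O)C=C[C@@H]1O` differs from compound 3 by hydrogen in place of acetyl on an oxygen on a saturated carbon. Two measured steps remove an acetyl from an oxygen on a saturated carbon: a 1.3-fold higher number from compound 1 to compound 2 (0.11 log units; within the scatter) and an 11-fold lower number from compound 1 to compound 3 (1.03 log units; beyond the scatter). Compound 2 carries hydrogen at the same oxygen where compound 4 does, so the step from compound 1 to compound 2 is the closer guide, and it stayed within the scatter. A step of a 1.3-fold higher number from compound 3 to compound 4 (0.12 log units; within the scatter) is therefore expected, and compound 4 is estimated at 400 nM, with a range from 150 nM to 1200 nM.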

Compound 4, half-maximal inhibitory concentration: 6200 nM
For compound 4 the middle estimate is 16-fold (1.19 log units) below the measured one, outside the stated range (above it).
By their numbers in this assay, from the lowest: compound 3; then compounds 1, 2 and 4 (each within the scatter of the next).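

In this assay, the change from acetoxy to hydroxy at this position, which stayed within the scatter on the core of compound 1, gives a 21-fold higher number from compound 3 to compound 4 (1.32 log units; beyond the scatter), so its size depends on whether the other acetyl is present: the same change on two cores in this assay, a 1.3-fold higher number (0.11 log units; within the scatter) from compound 1 to compound 2 and a 21-fold higher number (1.32 log units; beyond the scatter) from compound 3 to compound 4, 16-fold (1.21 log units) apart, beyond the scatter of two such steps Removing that other acetyl depends in turn on this position, giving only a 1.5-fold higher number from compound 2 to compound 4 (0.18 log units; within the scatter) once hydroxy already stands here: the same change on two cores in this assay, an 11-fold lower number (1.03 log units; beyond the scatter) from compound 1 to compound 3 and a 1.5-fold higher number (0.18 log units; within the scatter) from compound 2 to compound 4, 16-fold (1.21 log units) apart, beyond the scatter of two such steps The two acetyl groups therefore do not act independently, and only compound 3 stands apart from the rest.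

The compounds shown leave open whether this oxygen needs an acetyl specifically, or whether a butyryl ester or a methyl ether would serve as well.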